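Expected Inhibition After a Dichlorophenyl Exchange on Compound 2

The compounds below may be only part of what the source reports. "The series", "measured", "known", "first", "only" and "open" are said of these compounds alone.

Of the compounds shown here, three sharing one core have been measured in a functional assay, with a stated time of 6 min; on this read-out higher numbers stand for weaker inhibition and lower numbers for stronger inhibition. Compound 1 `S=c1oc(-c2ccc3c(c2)OCCO3)nn1CNc1ccccc1` gives 5140 nM. Compound 2 `COc1ccc(NCn2nc(-c3ccc4c(c3)OCCO4)oc2=S)cc1` gives 5830 nM, and compound 3 `Fc1ccc(NCn2nc(-c3ccc4c(c3)OCCO4)oc2=S)cc1` gives 6480 nM. Compound 2 stands second highest of the three numbers, with compound 3 nearest and compound 1 furthest, yet every pair lies within the scatter, so no order among them can be drawn. The measured steps are a 1.1-fold higher number from compound 1 to compound 2 (0.05 log units; within the scatter), a 1.3-fold higher number from compound 1 to compound 3 (0.10 log units; within the scatter) and a 1.1-fold higher number from compound 2 to compound 3 (0.05 log units; within the scatter), all within the scatter.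

Compound 4 `S=c1oc(-c2ccc3c(c2)OCCO3)nn1CNc1cc(Cl)ccc1Cl` awaits measurement. It differs from compound 2 by 2,5-dichlorophenyl in place of 4-methoxyphenyl on an amine nitrogen. For the measured compounds named here, no measured step covers this exchange; the steps that bear on it change only a single hydrogen, methoxy or fluoro on the same ring, and none moved the read-out beyond the scatter. The expectation is therefore a small step, if any, in this assay, with no direction favoured: compound 4 is estimated at 5500 nM, within 2000 nM to 15000 nM, which is expected to mean a 1.1-fold lower number from compound 2 to compound 4 (0.03 log units; within the scatter).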

Compound 4, half-maximal inhibitory concentration: 5420 nM
Compound 4: middle estimate off by 1.0-fold (0.01 log units), on the high side, within the range that was stated.
By their numbers in this assay, from the lowest: compounds 1, 4, 2 and 3 (each within the scatter of the next).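

In this assay, for the compounds shown here, the earlier compounds varied only a single group on the ring, whereas here the whole of 2,5-dichlorophenyl, with its two chlorine atoms, enters on the amine nitrogen and no readable step follows (a 1.1-fold lower number from compound 2 to compound 4 (0.03 log units; within the scatter); a 1.2-fold lower number from compound 3 to compound 4 (0.08 log units; within the scatter); a 1.1-fold higher number from compound 1 to compound 4 (0.02 log units; within the scatter)). The exchange also removes the hydrogen-bond acceptor counted for 4-methoxyphenyl, and that loss comes with no step beyond the scatter. Among these compounds, then, phenyl, 4-methoxyphenyl, 4-fluorophenyl and 2,5-dichlorophenyl cannot be told apart at this position.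

As far as these compounds go, it remains open whether a different kind of group here, such as a carboxylic acid on the phenyl ring, a cyclohexyl ring or a longer chain, would move the number beyond the scatter. Nothing measured here bears on why these four compounds cannot be separated.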